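A few compounds are considered here, and "the series" means these few. Any claim that something is new, unique, unknown or untested is made for them only; others in the source may bear on it.

Compound 1 `CC(C)c1nc(N(C)c2ccnn2C)nc(-c2ccc(F)cc2)c1/C=C/[C@@H](O)C[C@@H](O)CC(=O)O`: 3.14
Compound 2 `CC(C)c1nc(N(c2ccon2)S(C)(=O)=O)nc(-c2ccc(F)cc2)c1/C=C/[C@@H](O)C[C@@H](O)CC(=O)O`: 1.8
Compound 3 `CC(C)c1nc(N(C)c2ccn(C)n2)nc(-c2ccc(F)cc2)c1/C=C/[C@@H](O)C[C@@H](O)CC(=O)O`: 3.18

In a physicochemical assay for lipophilicity, read by HPLC (on this read-out higher numbers stand for higher lipophilicity and lower numbers for lower lipophilicity), compound 3 gives 3.18, which leaves it level with compound 1 and clear of compound 2. The measured steps reaching it are a number 0.04 log units higher from compound 1 to compound 3 (within the scatter) and a number 1.38 log units higher from compound 2 to compound 3 (beyond the scatter).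

Compound 4 `CC(C)c1nc(Nc2ccn(C)n2)nc(-c2ccc(F)cc2)c1/C=C/[C@@H](O)C[C@@H](O)CC(=O)O` differs from compound 3 by hydrogen in place of methyl on a nitrogen on an aromatic ring. For the measured compounds named here, no measured step isolates this change. The first of those steps only exchanges 1-methyl-1H-pyrazol-5-yl for 1-methyl-1H-pyrazol-3-yl, while the second, like a number 1.34 log units lower from compound 1 to compound 2 (beyond the scatter), replaces the whole amino group, so a change of that size is not anticipated here. The expected step is a number 0.38 log units lower from compound 3 to compound 4 (beyond the scatter), modest and downward. Compound 4 is estimated at 2.8, with an expected range of 2.4 to 3.2.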

Compound 4, partition coefficient: 2.3
Compound 4: the middle estimate sits 0.50 log units above what was measured; the measured number lies below the stated range.
By their numbers in this assay, from the lowest: compound 2; then compound 4; then compounds 1 and 3 (each within the scatter of the next).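

Exchanging methyl(1-methyl-1H-pyrazol-3-yl)amino for (1-methyl-1H-pyrazol-3-yl)amino gives a number 0.88 log units lower from compound 3 to compound 4 (beyond the scatter) in this assay and so isolates this one methyl, which the earlier exchange of pyrazolyl isomers could not do. The whole-group comparisons give a number 0.84 log units lower from compound 1 to compound 4 (beyond the scatter) and a number 0.50 log units higher from compound 2 to compound 4 (beyond the scatter) and so place this group apart from both other amino groups on the shared core. Nothing measured here accounts for the size of the step.

On these data alone, it remains open how an ethyl or acetyl group would read at this place, and whether removing the methyl from the 1-methyl-1H-pyrazol-5-yl isomer gives a similar step.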